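From a tert-butyl ester to a 3-methylphenyl ester

A few compounds are considered here, and "the series" means these few. Any claim that something is new, unique, unknown or untested is made for them only; others in the source may bear on it.

Three esters built on a shared core have been measured in a toxicity assay on HEK-293T cells (Homo sapiens) for cytotoxicity, read by MTT assay, with a stated time of 48 h; a lower number here means a stronger inhibitor, a higher number a weaker inhibitor. Compound 1 `C=C1[C@H](OC(C)=O)[C@@H](OC(C)=O)[C@@H](OC(C)=O)C(C)(C)/C=C/[C@H](C)[C@H](OC(=O)c2ccccc2)[C@@]2(O)C[C@@](C)(OC(C)=O)[C@H](OC(C)=O)[C@@H]2[C@H]1OCC(C)C` gives 26100 nM, compound 2 `C=C1[C@H](OC(C)=O)[C@@H](OC(C)=O)[C@@H](OC(C)=O)C(C)(C)/C=C/[C@H](C)[C@H](OC(=O)c2ccccc2)[C@@]2(O)C[C@@](C)(OC(=O)c3ccncc3)[C@H](OC(C)=O)[C@@H]2[C@H]1OCC(C)C` gives 19500 nM, and compound 3 `C=C1[C@H](OC(C)=O)[C@@H](OC(C)=O)[C@@H](OC(C)=O)C(C)(C)/C=C/[C@H](C)[C@H](OC(=O)c2ccccc2)[C@@]2(O)C[C@@](C)(OC(=O)C(C)(C)C)[C@H](OC(C)=O)[C@@H]2[C@H]1OCC(C)C` gives 56300 nM, the highest of the three numbers. Compound 4 `C=C1[C@H](OC(C)=O)[C@@H](OC(C)=O)[C@@H](OC(C)=O)C(C)(C)/C=C/[C@H](C)[C@H](OC(=O)c2ccccc2)[C@@]2(O)C[C@@](C)(OC(=O)c3cccc(C)c3)[C@H](OC(C)=O)[C@@H]2[C@H]1OCC(C)C` differs from compound 3 by 3-methylphenyl in place of tert-butyl on a carbonyl carbon. Within the data shown here, two measured steps bear on this change: a 2.2-fold higher number from compound 1 to compound 3 (0.33 log units; beyond the scatter) and a 2.9-fold higher number from compound 2 to compound 3 (0.46 log units; beyond the scatter), so both departures from tert-butyl at this carbonyl carbon ran toward lower numbers, and compound 2 carries pyridin-4-yl, an aromatic ring, at the same position. Compound 4 is therefore expected to move back toward lower numbers, with a 2.6-fold lower number from compound 3 to compound 4 (0.41 log units; beyond the scatter). The estimate for compound 4 in this assay is 22000 nM, within a range of 9000 nM to 50000 nM.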

Compound 4, half-maximal inhibitory concentration: 7220 nM
Estimate against measurement, compound 4: 3.0-fold (0.48 log units) above; the whole stated range lies above it.
By their numbers in this assay, from the lowest: compound 4; then compounds 2 and 1 (each within the scatter of the next); then compound 3.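

In this assay the 3-methylphenyl ester gives the largest step seen at this carbonyl carbon, a 7.8-fold lower number from compound 3 to compound 4 (0.89 log units; beyond the scatter), and compound 4 has the lowest number of the four. An aromatic ring alone does not settle the number, as pyridin-4-yl and 3-methylphenyl differ by a 2.7-fold lower number from compound 2 to compound 4 (0.43 log units; beyond the scatter), while the acetate, with its methyl on the carbonyl carbon, lies further off at a 3.6-fold lower number from compound 1 to compound 4 (0.56 log units; beyond the scatter). No measurement here accounts for these differences. Still open, going by these compounds, is whether the methyl on the ring matters, which a plain phenyl ester would test. A ring carrying an amine or a carboxylic acid is equally untested.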